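A chalcone pyrazole series at the assay ceiling

The source may report more compounds than this note shows. Statements on the series, on what has been measured and on what is new or still open speak of the compounds shown alone.

The shared core carries a trimethoxyphenyl on one side of the pyrazole and an aryl ketone on the other. Compound 1 `COc1cc(-c2cc(/C=C/C(=O)c3ccc(Cl)c(Cl)c3)[nH]n2)cc(OC)c1OC` bears a 3,4-dichlorophenyl on the carbonyl carbon. In a functional assay on CCRF-CEM cells (Homo sapiens) for inhibition, read by sulforhodamine B assay, with a stated time of 48 h (on this read-out lower numbers stand for higher toxicity in this test and higher numbers for lower toxicity in this test), compound 1 reaches only a limit of the assay, > 100000 nM. Compound 2 `COc1ccc(C(=O)/C=C/c2cc(-c3cc(OC)c(OC)c(OC)c3)n[nH]2)cc1OC` carries a 3,4-dimethoxyphenyl there. In this assay compound 2 likewise shows only a limit, > 100000 nM. Compound 3 `COc1cc(-c2cc(/C=C/C(=O)c3ccc(F)c(F)c3)[nH]n2)cc(OC)c1OC` has a 3,4-difluorophenyl. In this assay compound 3 is also given as a limit, > 100000 nM. Because of the limit of > 100000 nM in this assay, at which 3 of the 3 values shown sit, the steps a step that the two limits leave unreadable from compound 1 to compound 2, a step that the two limits leave unreadable from compound 1 to compound 3 and a step that the two limits leave unreadable from compound 2 to compound 3 cannot be sized.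

Compound 4 `COc1cc(C(=O)/C=C/c2cc(-c3cc(OC)c(OC)c(OC)c3)n[nH]2)cc(OC)c1OC` differs from compound 2 by methoxy in place of hydrogen on an aromatic carbon. For the measured compounds named here, no measured step reads a size for such a change; all three neighbours sit at the same limit. The expected outcome is that compound 4 also stays at or beyond the limit, so the estimated step that the limit leaves unreadable from compound 2 to compound 4 is one not readable beyond the scatter. Compound 4 is therefore estimated at 150000 nM, within 60000 nM to 400000 nM.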

Compound 4, concentration lethal to 50% of the cells: > 100000 nM
Compound 4: a limit, no number; the forecaster's own chance of this, stated with the estimate: 85%; the middle value is on the limit's open side.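

No size can be read for the change from compound 2 to compound 4, because both compounds stand at the same limit: the limit of > 100000 nM in this assay, at which 4 of the 4 values shown sit. The compounds shown leave open whether any group on the carbonyl carbon moves the read-out in this assay at all.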